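The compounds below may be only part of what the source reports. "The series", "measured", "known", "first", "only" and "open" are said of these compounds alone.

Measured in an ADME assay on HaCaT cells (Homo sapiens) for cytotoxicity, read by sulforhodamine B assay, with a stated time of 48 h; a higher number here means a weaker inhibitor of growth, a lower number a stronger inhibitor of growth:
- compound 1, `COc1ccc2cc(CCCn3nnnc3-c3ccccc3)oc(=O)c2c1`. Compound 1 sits at the assay limit >= 250 ug/mL.
- compound 2, `COc1ccc2c(c1)C(=O)OC(CO)C2`. Compound 2 sits at the assay limit >= 250 ug/mL.
- compound 3, `COc1ccc2c(c1)C(=O)OC(CCCO)C2`. Compound 3 gives 130 ug/mL.

Among the compounds with values here, compound 3 holds the only real number in this assay; the other two values are limits, as recorded in the limit of >= 250 ug/mL in this assay, at which 2 of the 3 values shown sit. Within the data shown here, the single measured step between neighbours is an at least 1.9-fold lower number from compound 2 to compound 3 (0.28 log units; that floor lies within the scatter), and its floor lies within the scatter, so it gives direction only weakly.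

Compound 4, `CCCCCOCCCC1Cc2ccc(OC)cc2C(=O)O1`, differs from compound 3 thus: pentyl in place of hydrogen on an oxygen on a saturated carbon. Among the measured compounds shown here, the one step that bears on it, an at least 1.9-fold lower number from compound 2 to compound 3 (0.28 log units; that floor lies within the scatter), also grew the same side chain and moved the number downward by an amount whose floor is within the scatter; no measured step caps the oxygen with an alkyl group, so that part of the change is untested. In this assay a modest further lowering is expected for compound 4, a 1.9-fold lower number from compound 3 to compound 4 (0.27 log units; within the scatter), with wide uncertainty. Compound 4 is therefore estimated at 70 ug/mL, expected between 25 ug/mL and 200 ug/mL.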

Compound 4, concentration for 50% growth inhibition: 32.3 ug/mL
Compound 4: the middle estimate sits 2.2-fold (0.34 log units) above what was measured; the measured number falls inside the stated range.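

Pentyl in place of hydrogen on an oxygen on a saturated carbon gives the first step in the series that clearly moves the number in this assay: a 4.0-fold lower number from compound 3 to compound 4 (0.60 log units; beyond the scatter). The side chain therefore tolerates capping of this oxygen, and the direction only weakly suggested by the earlier step, an at least 1.9-fold lower number from compound 2 to compound 3 (0.28 log units; that floor lies within the scatter), now holds for a further change to the same chain. Compound 3 and compound 4 are also the only pair here in which both values are numbers rather than limits: the limit of >= 250 ug/mL in this assay, at which 2 of the 4 values shown sit.

A single alkyl group on this oxygen cannot show whether the lowering follows chain length or comes from capping the hydroxy at all; methoxy or a longer chain such as decyloxy would separate the two. From the compounds shown here alone, whether the oxygen itself matters also stays open, and an amine in its place would test that.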